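Side-chain swap carried from one core to the other

The source may report more compounds than this note shows. Statements on the series, on what has been measured and on what is new or still open speak of the compounds shown alone.

Compound 1 `CC(C)[C@H](NC(=O)CN(c1nc(Cl)nc2[nH]cnc12)C1CC1)C(=O)OCc1ccccc1` and compound 2 `CSCC[C@H](NC(=O)CN(c1nc(Cl)nc2[nH]cnc12)C1CC1)C(=O)OCc1ccccc1` share one core; compound 3 `CSCC[C@H](NC(=O)CN(c1ncnc2c1ncn2C1CCCCO1)C1CC1)C(=O)OCc1ccccc1` and the not yet measured compound 4 `CC(C)[C@H](NC(=O)CN(c1ncnc2c1ncn2C1CCCCO1)C1CC1)C(=O)OCc1ccccc1` share a second. In a functional assay on the whole organism (Tail, strain ICR) with Mus musculus as the target, in the tail flick test, with a stated time of 30 min, at a dose of 25 umol/kg by the oral route (a lower number here means a weaker effect, a higher number a stronger effect of the compound at the dose given), compound 1 gives 33.4%, compound 2 gives 22.2% and compound 3 gives 30%. The difference between the two cores is not broken down here. On the first core, compound 1 differs from compound 2 by isopropyl in place of 2-(methylsulfanyl)ethyl on a saturated chain carbon bound to an amide-type nitrogen and a carbonyl carbon, and this change produced a number 11.2 percentage points higher from compound 2 to compound 1 (beyond the scatter). Compound 4 differs from compound 3 by isopropyl in place of 2-(methylsulfanyl)ethyl on a saturated chain carbon bound to an amide-type nitrogen and a carbonyl carbon, the same change at the same place; it occurs twice among these four compounds. The values of compound 3 and compound 1 lie within the scatter of each other, as do those of compound 3 and compound 2. Within the data shown here, the step from compound 3 to compound 4 is expected at a number 8 percentage points higher from compound 3 to compound 4 (within the scatter), set a little below the earlier one because a number 11.2 percentage points higher from compound 2 to compound 1 (beyond the scatter) is the only measured instance of this change and stands on a different core. Compound 4 is therefore estimated at 38%, with a likely range from 26% to 50%.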

Compound 4, a percentage reported as activity, at one dose (the size of the read-out at that dose, not a potency): 21.8%
Compound 4: the middle estimate sits 16.2 percentage points above what was measured, and the stated range ends above it.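

In this assay, isopropyl in place of 2-(methylsulfanyl)ethyl on a saturated chain carbon bound to an amide-type nitrogen and a carbonyl carbon gives a number 8.2 percentage points lower from compound 3 to compound 4 (within the scatter), so the rise seen on the core of compound 1 does not recur on the core of compound 3. Set side by side, the two steps disagree: the same change on two cores in this assay, a number 11.2 percentage points higher (beyond the scatter) from compound 2 to compound 1 and a number 8.2 percentage points lower (within the scatter) from compound 3 to compound 4, 19.4 percentage points apart, beyond the scatter of two such steps. The change therefore does not carry over from one core to the other as a fixed increment in this series, but with a single pair per core the notes show neither why the steps part nor any reversal on the second core, whose step stays within the scatter.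

On these data alone, only isopropyl and 2-(methylsulfanyl)ethyl are compared on both cores, so it remains open whether a longer chain, an amine or a carboxylic acid at this place would also behave differently on the two cores. The two cores differ in more than one place, and no compound shown separates which of those differences goes with the disagreement.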